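The source may hold more compounds than are shown below. What is called first, only, known or untested is meant among the compounds shown, and "the series" means these compounds.

Measured compounds in cytotoxicity testing:
- compound 1 `CCc1ccc(-c2nc3c(c(C)nn3-c3ccccc3)c(-c3ccccc3[N+](=O)[O-])c2C#N)cc1`: a limit, > 20000 nM
- compound 2 `CCc1ccc(-c2nc3c(c(C)nn3-c3ccccc3)c(-c3ccccc3C#N)c2C#N)cc1`: a limit, > 20000 nM
- compound 3 `Cc1nn(-c2ccccc2)c2nc(-c3ccc(C#N)cc3)c(C#N)c(-c3ccccc3O)c12`: a limit, > 20000 nM

All three were tested in an ADME assay on BJ cells (Homo sapiens) for cytotoxicity, with a stated time of 72 h; a higher number here means that more compound is needed for the effect, a lower number that less compound is needed. None of them gave a number, only the limit of the assay, and the limit of > 20000 nM in this assay, at which 3 of the 3 values shown sit, summarises this. Compounds 1 and 2 share a core and differ by nitro in place of cyano on an aromatic carbon; the step that the two limits leave unreadable from compound 2 to compound 1 therefore cannot be read, since both values are limits. Compound 3 has a different core, and the difference between the two cores is not broken down here.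

Compound 4 `Cc1nn(-c2ccccc2)c2nc(-c3ccc([N+](=O)[O-])cc3)c(C#N)c(-c3ccccc3O)c12` is not yet measured. It differs from compound 3 by nitro in place of cyano on an aromatic carbon. For the measured compounds named here, this is the same kind of change as the one from compound 2 to compound 1, but the place differs: in compound 1 the new group sits ortho to a large group, in compound 4 para to a large group. Because compound 3 gives only a limit, > 20000 nM, and because the step that the two limits leave unreadable from compound 2 to compound 1 is unreadable, the expected step of a number no higher from compound 3 to compound 4 (the limit leaves the size open) rests on little. Compound 4 is estimated to reach 20000 nM, most likely again as a limit.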

Compound 4, half-maximal effective concentration in the BJ assay: > 20000 nM
Compound 4 was reported as a limit (the forecaster's own chance of this, stated with the estimate: 80%); the middle value lies on the limit itself.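

In the BJ assay, compound 3 gives only a limit of the assay, > 20000 nM, rather than a number. In the BJ assay, compound 4 also gives only a limit of the assay, > 20000 nM, rather than a number. No step can be read between them. The compounds shown leave open at what concentration any of them would harm these cells, and whether nitro in place of cyano changes that concentration at all. In a physicochemical assay for solubility, read by spectrophotometry, in phosphate buffer, with a stated time of 18 h, at pH 7.4 (a lower number here means a less soluble compound, a higher number a more soluble compound), compound 3 gives 1700 nM and compound 4 gives 6000 nM. In the physicochemical assay, nitro in place of cyano goes with a 3.5-fold higher number from compound 3 to compound 4 (0.55 log units; beyond the scatter).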